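Swapping one ring for another at one aromatic carbon

The source may hold more compounds than are shown below. What is called first, only, known or untested is meant among the compounds shown, and "the series" means these compounds.

Compound 1 `O=S(=O)(Nc1nccs1)c1ccc2c(c1)OCC[C@H]2c1ccc(C(F)(F)F)cc1-c1nccs1` gives 3.3
Compound 2 `O=C1OCCN1c1cc(C(F)(F)F)ccc1[C@H]1CCOc2cc(S(=O)(=O)Nc3nccs3)ccc21` gives 2.1
Compound 3 `Cn1nccc1-c1cc(C(F)(F)F)ccc1[C@@H]1CCOc2cc(S(=O)(=O)Nc3nccs3)ccc21` gives 2.2

In a physicochemical assay for lipophilicity (a higher number here means a more lipophilic compound, a lower number a more polar compound), compound 2 (2.1) sits within the scatter of compound 3 (2.2), and both lie clearly under compound 1 (3.3). Compound 4 `O=C1COCCN1c1cc(C(F)(F)F)ccc1[C@H]1CCOc2cc(S(=O)(=O)Nc3nccs3)ccc21` has not yet been measured. It differs from compound 2 in a single place: 3-oxomorpholin-4-yl in place of 2-oxo-1,3-oxazolidin-3-yl on an aromatic carbon and there, on an aromatic carbon meta to a trifluoromethyl group, 3-oxomorpholin-4-yl takes the place of 2-oxo-1,3-oxazolidin-3-yl. A six-membered non-aromatic ring thus replaces a five-membered one. Among the compounds with values here, only one measured step offers any guide: a number 1.10 log units lower from compound 1 to compound 3 (beyond the scatter) was large, but it exchanged 1,3-thiazol-2-yl for 1-methyl-1H-pyrazol-5-yl, a quite different swap. It shows that a change on an aromatic carbon can move this number, yet its size does not carry over to so small an exchange. The expected result is a number 0.10 log units higher from compound 2 to compound 4 (within the scatter) and no move beyond the scatter. For compound 4 the estimate is 2.2 (expected range 1.8 to 2.6).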

Compound 4, distribution coefficient: 1.8
Compound 4: the middle estimate sits 0.40 log units above what was measured; the range from low to high includes it.
By their numbers in this assay, from the lowest: compounds 4, 2 and 3 (each within the scatter of the next, the first and the last beyond it); then compound 1.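

In this assay, with a number 0.30 log units lower from compound 2 to compound 4 (within the scatter), 3-oxomorpholin-4-yl took the place of 2-oxo-1,3-oxazolidin-3-yl without a move beyond the scatter. This shows that, on this aromatic carbon meta to a trifluoromethyl group, a six-membered non-aromatic ring can replace a five-membered one and leave the reading in the same band. Within the data shown here, the earlier compounds offered only one step at this carbon, a number 1.10 log units lower from compound 1 to compound 3 (beyond the scatter), which exchanged 1,3-thiazol-2-yl for 1-methyl-1H-pyrazol-5-yl, whereas compound 2 and compound 4 compare two non-aromatic rings with the same counts of hydrogen-bond donors and acceptors.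

The compounds shown leave open whether the reading would stay in this band with a group of another kind on this carbon, such as an open-chain amine or a carboxylic acid. No supporting data bear on what lies behind this result.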